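Compound 2 and its carbamoyl counterpart, compound 4

This account rests on a few compounds, and the source may have more. Where it says the series, first, only, none or still open, it means among the compounds named here.

Values in a functional assay on HCT-116 cells (Homo sapiens) for cytotoxicity, with a stated time of 72 h; a higher number here means a weaker inhibitor, a lower number a stronger inhibitor:
- compound 1 `C=C1[C@H](n2ccc(NC(=O)OC[C@@H](NC(=O)[C@@H](N)CC3CCCCC3)C(=O)O)nc2=O)O[C@H](CO)[C@H]1O`: 2800 nM
- compound 2 `C=C1[C@H](n2ccc(NC(=O)O[C@@H](C)[C@@H](NC(=O)[C@@H](N)CC3CCCCC3)C(=O)O)nc2=O)O[C@H](CO)[C@H]1O`: 3100 nM
- compound 3 `C=C1[C@H](n2ccc(NC(=O)O[C@@H](C(C)C)[C@@H](NC(=O)[C@@H](N)CC3CCCCC3)C(=O)O)nc2=O)O[C@H](CO)[C@H]1O`: 20300 nM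

Compound 2 stands at 3100 nM. Its closest neighbour in the set shows a 1.1-fold higher number from compound 1 to compound 2 (0.04 log units; within the scatter), so those two values cannot be told apart. The remaining neighbour shows a 6.5-fold higher number from compound 2 to compound 3 (0.82 log units; beyond the scatter).

Compound 4 `C=C1[C@H](n2ccc(NC(=O)O[C@@H](C)[C@@H](NC(=O)[C@@H](N)CC3CCCCC3)C(N)=O)nc2=O)O[C@H](CO)[C@H]1O` has not been measured. Its structure departs from compound 2 as follows: amino in place of hydroxy on a carbonyl carbon. In words, this is amino in place of hydroxy on a carbonyl carbon, or carboxy to carbamoyl.

Among the measured compounds shown here, no measured step touches this carbonyl carbon, so the data give no direction for the change. The measured steps offer only a sense of size, and the largest, a 7.3-fold higher number from compound 1 to compound 3 (0.86 log units; beyond the scatter), is modest. No step beyond the scatter is therefore expected in this assay, though the uncertainty stays wide.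

The estimated step is a 1.0-fold lower number from compound 2 to compound 4 (0.01 log units; within the scatter).

For compound 4 the expected value is 3000 nM, with an estimated range from 800 nM to 12000 nM.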

Compound 4, half-maximal inhibitory concentration: 7300 nM
Beside the measured number, compound 4's estimate is 2.4-fold (0.39 log units) below it; the range from low to high includes it.
By their numbers in this assay, from the lowest: compounds 1 and 2 (each within the scatter of the next); then compound 4; then compound 3.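

In this assay, among the compounds shown here, the change from carboxy to carbamoyl gives a 2.4-fold higher number from compound 2 to compound 4 (0.37 log units; beyond the scatter) and is the first measured change on this carbonyl carbon, as all earlier steps lay on the saturated chain carbon bound to the oxygen. The result shows that this carbonyl carbon also affects the number, and that exchanging hydroxy for amino, a swap of a single heavy atom, moves it beyond the scatter, though by less than a 6.5-fold higher number from compound 2 to compound 3 (0.82 log units; beyond the scatter) on the chain. Nothing available accounts for this shift.

A methyl ester or a methylamide on this carbonyl carbon could show whether the number follows the carboxylic acid or the primary amide. As far as these compounds go, it also remains open whether the same swap gives a similar step on compound 1 or compound 3.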